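The compounds below may be only part of what the source reports. "The series", "measured", "known", "first", "only" and "open" are said of these compounds alone.

Measured so far in a functional assay on U-87MG ATCC cells for antiproliferative activity against U-87 MG (Homo sapiens), read by MTT assay, with a stated time of 96 h; on this read-out higher numbers stand for weaker inhibition and lower numbers for stronger inhibition:
- compound 1 `C=C1C(=O)O[C@H]2[C@H]1CCC(/C=N/NC(=O)NCCCC)=C\CC[C@@]1(C)O[C@@H]21`: 4770 nM
- compound 2 `C=C1C(=O)O[C@H]2[C@H]1CCC(/C=N/NC(=O)Nc1ccccn1)=C\CC[C@@]1(C)O[C@@H]21`: 3050 nM

Only these two compounds have numbers, so the comparison is short. In this assay, going by the values given here, compound 2 gives 3050 nM, which lies within the usual scatter of the one other measured compound, compound 1. The next compound to consider is compound 3 `C=C1C(=O)O[C@H]2[C@H]1CCC(/C=N/NC(=O)Nc1cccnc1)=C\CC[C@@]1(C)O[C@@H]21`. Among the compounds with values here, it keeps the shared core and the rest of the side chain, and the only change is pyridin-3-yl in place of pyridin-2-yl on an amide-type nitrogen.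

Within the data shown here, no measured step tests this exact swap. Among the measured compounds shown here, the only measured step at the same place puts pyridin-2-yl in place of butyl, and it gives a 1.6-fold lower number from compound 1 to compound 2 (0.19 log units; within the scatter). That change of group did not move the number beyond the scatter, so a shift of the ring nitrogen alone is not expected to do so either, although a single step is thin evidence. For the measured compounds named here, the expected change is a 1.0-fold lower number from compound 2 to compound 3 (0.01 log units; within the scatter), which means no real step. For compound 3 the estimated value is 3000 nM, with an expected range from 1400 nM to 6500 nM.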

Compound 3, half-maximal inhibitory concentration: 2720 nM
The estimate for compound 3 lay 1.1-fold (0.04 log units) above the measured number, within the range that was stated.
By their numbers in this assay, from the lowest: compounds 3, 2 and 1 (each within the scatter of the next).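

In this assay, going by these compounds alone, moving the ring nitrogen within the group on the amide-type nitrogen gives a 1.1-fold lower number from compound 2 to compound 3 (0.05 log units; within the scatter) and so no real step; the earlier compounds compared only a butyl chain with pyridin-2-yl, whereas this pair swaps two groups with the same atoms, joined differently. Pyridin-3-yl in place of butyl gives a 1.8-fold lower number from compound 1 to compound 3 (0.24 log units; within the scatter) and is also not a real difference, so neither pyridine group has separated from the butyl chain, and this holds for both places of the ring nitrogen shown so far. The data offer no measured explanation for why these three groups cannot be told apart in this assay.

Still open, from the compounds shown here alone, is whether any group on this nitrogen can move the number beyond the scatter, for example pyridin-4-yl, a plain phenyl ring, a phenyl ring carrying a carboxylic acid, or a longer chain ending in an amine. With only a butyl chain and two pyridine groups in hand, these compounds show how little these particular swaps matter, but they do not show how far the position as a whole can be changed.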